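Swapping a saturated ring for a pyrazole at the amine

The compounds below may be only part of what the source reports. "The series", "measured", "known", "first", "only" and "open" are said of these compounds alone.

In a physicochemical assay for lipophilicity, using the shake flask method, measured as octanol-water partition, with a stated time of 30 min, at pH 7.4 (a higher number here means a more lipophilic compound, a lower number a more polar compound), two compounds have been measured. Compound 1 `COCc1ccc(-c2ccc3nnc(C(N)=O)c(N[C@@H](C)c4ccn(C)n4)c3c2)cn1` gives 3. Compound 2 `C[C@H](Nc1c(C(N)=O)nnc2ccc(-c3ccc(OCCCN4CCCC4)nc3)cc12)C1CCOCC1` gives 1.9, the lower of the two numbers and, as the gap to compound 1 lies beyond the scatter, distinctly the more polar of the pair. Compound 3 `C[C@H](Nc1c(C(N)=O)nnc2ccc(-c3ccc(OCCCN4CCCC4)nc3)cc12)c1ccn(C)n1` has not yet been measured in this assay. It differs from compound 2 in one place: 1-methyl-1H-pyrazol-3-yl in place of oxan-4-yl on a saturated chain carbon bound to a nitrogen on an aromatic ring and a saturated chain carbon. For the measured compounds named here, no directly comparable step between measured compounds exists, so the size of this change can only be estimated. The two groups carry the same count of heavy atoms, and one ring is exchanged for another of similar size, so no large shift in either direction is expected. On that basis compound 3 is expected to give about 1.8 in this assay, with a plausible range from 1.3 to 2.3. The estimated step of a number 0.10 log units lower from compound 2 to compound 3 (within the scatter) would thus stay within the usual scatter of repeated measurements, or at most be a small decrease.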

Compound 3, distribution coefficient: 1.8
Beside the measured number, compound 3's estimate shows no gap at the digits printed, within the range that was stated.
By their numbers in this assay, from the lowest: compounds 3 and 2 (each within the scatter of the next); then compound 1.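

In this assay, putting 1-methyl-1H-pyrazol-3-yl in place of oxan-4-yl on a saturated chain carbon bound to a nitrogen on an aromatic ring and a saturated chain carbon gives a number 0.10 log units lower from compound 2 to compound 3 (within the scatter), so at this place a six-membered non-aromatic ring and a five-membered aromatic ring with the same count of heavy atoms cannot be told apart by this read-out. The new compound also isolates a change at the other end of the molecule: 3-(pyrrolidin-1-yl)propoxy in place of methoxymethyl on an aromatic carbon gives a number 1.20 log units lower from compound 1 to compound 3 (beyond the scatter), a large step, so among these compounds the number follows that group and not the ring on the chain carbon. No measurement at hand explains the size of either step.

As far as these compounds go, whether the ring swap stays this quiet with methoxymethyl on the aromatic carbon remains open, as does the outcome for another ring on the chain carbon, such as a plain phenyl ring. From the compounds shown here alone, it is equally open how much of the large step would remain with a shorter chain, such as 2-(pyrrolidin-1-yl)ethoxy, or with a morpholine ring at the end of the chain.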